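Swapping the Hydrazone Aryl Group on a Shared Core

The source may hold more compounds than are shown below. What is called first, only, known or untested is meant among the compounds shown, and "the series" means these compounds.

Going by the values given here, compound 1 `COC(=O)c1cc(-c2csc(N/N=C/c3cccs3)n2)ccc1OCc1ccccc1` is one of two compounds measured in a functional assay, read by spectrophotometry, with a stated time of 15 min; on this read-out lower numbers stand for stronger inhibition and higher numbers for weaker inhibition; there compound 1 gives 28.1 ug/mL. Compound 2 `Fc1ccc(-c2csc(N/N=C/c3ccc(Cl)cc3Cl)n2)cc1` carries the same 2,4-dichlorophenyl hydrazone that appears in the new design, on a different aryl partner, and in this assay compound 2 gives 27.1 ug/mL. Compound 1 has the higher of the two numbers, but the gap to compound 2 lies within the usual scatter, so the two values show no difference that can be read as a real one.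

Compound 3 `COC(=O)c1cc(-c2csc(N/N=C/c3ccc(Cl)cc3Cl)n2)ccc1OCc1ccccc1` has not yet been measured. It differs from compound 1 in one place: 2,4-dichlorophenyl in place of thiophen-2-yl on a carbon with a double bond to nitrogen. Among the compounds with values here, no measured pair isolates exactly this change. What the data do show is that compound 2, with the entering group in place, sits within the scatter of compound 1, which gives no ground to expect a shift in either direction. The expected step is therefore none beyond the scatter: a 1.1-fold lower number from compound 1 to compound 3 (0.03 log units; within the scatter). Compound 3 is estimated to give about 26 ug/mL in this assay, in a range from 13 ug/mL to 52 ug/mL.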

Compound 3, half-maximal inhibitory concentration: 88.8 ug/mL
For compound 3 the middle estimate is 3.4-fold (0.53 log units) below the measured one; the measured number lies above the stated range.
By their numbers in this assay, from the lowest: compounds 2 and 1 (each within the scatter of the next); then compound 3.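

On the shared core, the group on a carbon with a double bond to nitrogen proves to matter: with 2,4-dichlorophenyl in place of thiophen-2-yl, this assay gives a 3.2-fold higher number from compound 1 to compound 3 (0.50 log units; beyond the scatter), a modest step beyond the scatter and towards weaker inhibition. Going by these compounds alone, the earlier compounds offered no pair that isolated this change, so this is the first direct reading of this position, and on this core the thiophen-2-yl compound is the stronger inhibitor of the two. No measurement at hand accounts for the loss, so the step stands as an observation without an explanation.

This single step changes several things at once, replacing a five-membered aromatic ring bearing sulfur with a six-membered carbon ring bearing two chlorine atoms, so the compounds shown do not separate the ring from the chlorines. They leave open whether an unsubstituted phenyl, a 4-chlorophenyl or a furan-2-yl group at this position would stay close to compound 1 or fall closer to compound 3.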